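The compounds below may be only part of what the source reports. "The series", "measured", "known", "first", "only" and "open" are said of these compounds alone.

Measured so far:
- compound 1, `COc1cc(NC(C)CCCNC(=O)NCC2CCCCC2)c2ncccc2c1`: > 100000 nM
- compound 2, `COc1cc(NC(C)CCCNC(=O)NCc2ccccc2)c2ncccc2c1`: 30000 nM

In a functional assay on NCI-H460 cells (Homo sapiens), read by MTT assay, with a stated time of 72 h (on this read-out lower numbers stand for stronger inhibition and higher numbers for weaker inhibition), compound 1 gives only a limit, > 100000 nM, not a number. In this assay compound 2 gives 30000 nM. Among the compounds with values here, the one change measured between them is an at least 3.3-fold lower number from compound 1 to compound 2 (0.52 log units; beyond the scatter), and the size of that step is uncertain because compound 1 sits at the limit of > 100000 nM in this assay, at which 1 of the 2 values shown sits.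

Compound 3, `COc1cc(NC(C)CCCNC(=O)NC2CCCC2)c2ncccc2c1`, has not yet been measured. It differs from compound 1 in one place: cyclopentyl in place of cyclohexylmethyl on an amide-type nitrogen. Within the data shown here, no measured step covers this exact change. The only step shown, from compound 1 to compound 2, concerns a different part of the same group and shows that the cyclohexylmethyl end of compound 1 is linked with the weakest result seen. Moving to cyclopentyl removes the ring of compound 1 together with its connecting carbon, and there is no evidence that this would add inhibition. The expected step from compound 1 to compound 3 is therefore a number no higher from compound 1 to compound 3 (the limit leaves the size open), meaning compound 3 is expected to stay about where compound 1 lies. Compound 3 is estimated at 100000 nM, in a range from 35000 nM to 300000 nM, with a fair chance that this assay again reports only a limit.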

Compound 3, half-maximal inhibitory concentration: 25000 nM
Estimate against measurement, compound 3: 4.0-fold (0.60 log units) above, outside the stated range (below it).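

In this assay, putting cyclopentyl in place of cyclohexylmethyl on the amide-type nitrogen gives an at least 4.0-fold lower number from compound 1 to compound 3 (0.60 log units; beyond the scatter), so a measurable number at this position does not depend on an aromatic ring, as the benzyl group of compound 2 might have suggested. The step from the benzyl group to cyclopentyl is a 1.2-fold lower number from compound 2 to compound 3 (0.08 log units; within the scatter), so this assay does not tell these two groups apart. The true size of the step away from cyclohexylmethyl stays open because compound 1 gives only a limit, not a number: the limit of > 100000 nM in this assay, at which 1 of the 3 values shown sits.

Compound 1 and compound 3 differ both in ring size and in the connecting carbon, and the compounds shown do not separate these two changes; a cyclohexyl group set directly on the amide-type nitrogen would help to do so. Also open, from the compounds shown here alone, is whether a group of a different kind at this place, such as an amine or a carboxylic acid, would move the number well away from the values seen so far.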